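Fluorine beside the carbamate in a pyridylmethyl biphenyl series

The compounds below may be only part of what the source reports. "The series", "measured", "known", "first", "only" and "open" are said of these compounds alone.

Compound 1 `CC(=O)Nc1ccc(-c2ccc(Cc3ccncc3)cc2)cc1`: > 5000 nM in an assay for inhibition of steroid 17-alpha-hydroxylase/17,20 lyase (Homo sapiens); a higher number here means a weaker inhibitor, a lower number a stronger inhibitor
Compound 2 `COc1ccc(-c2ccc(Cc3ccncc3)cc2)cc1F`: 3340 nM
Compound 3 `CC(C)(C)OC(=O)Nc1ccc(-c2ccc(Cc3ccncc3)cc2)cc1`: 1370 nM

Compound 1 gives only a limit in this assay (the limit of > 5000 nM in this assay, at which 1 of the 3 values shown sits). Compound 3 gives the lowest of the two numbers, beyond the scatter from compound 2. Among the measured compounds shown here, the one counted step, an at least 3.6-fold lower number from compound 1 to compound 3 (0.56 log units; beyond the scatter), concerns the carbonyl carbon, not an aromatic position. Compound 4 `CC(C)(C)OC(=O)Nc1ccc(-c2ccc(Cc3ccncc3)cc2)cc1F` differs from compound 3 by fluoro in place of hydrogen on an aromatic carbon. No measured step touches this change; compound 2 carries fluoro, but its partner without fluoro is not shown, so its value alone says nothing about the fluoro. The step of a 1.1-fold lower number from compound 3 to compound 4 (0.06 log units; within the scatter) is therefore expected to stay within the scatter. Compound 4 is estimated at 1200 nM, between 500 nM and 3000 nM.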

Compound 4, half-maximal inhibitory concentration: > 10000 nM
Compound 4: only a limit was reported (the forecaster's own chance of this, stated with the estimate: 5%); middle value at least 8.3-fold (0.92 log units) from the limit.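

Compound 4 gives > 10000 nM in this assay as a limit of the assay. Fluoro ortho to a (tert-butoxycarbonyl)amino group gives an at least 7.2-fold higher number from compound 3 to compound 4 (0.86 log units; beyond the scatter) and is the first measured change at this aromatic carbon, where a single added fluorine weakens inhibition beyond the scatter. Fluoro alone does not set this outcome, as (tert-butoxycarbonyl)amino in place of methoxy gives an at least 2.9-fold higher number from compound 2 to compound 4 (0.47 log units; beyond the scatter) with fluoro present in both compounds.

As far as these compounds go, how far compound 4 lies past its limit remains open. Also open, from the compounds shown here alone, is whether chloro or methyl on this carbon, or a free amine in place of the (tert-butoxycarbonyl)amino group, would behave in the same way.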